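This account rests on a few compounds, and the source may have more. Where it says the series, first, only, none or still open, it means among the compounds named here.

Of the compounds shown here, three have been measured in a functional assay on MDA-MB-231 cells (Homo sapiens) for antiproliferative activity, read by MTT assay, with a stated time of 72 h; on this read-out higher numbers stand for weaker inhibition and lower numbers for stronger inhibition. Compound 1 `CC1=CC[C@H]2[C@@H]1CC=C(C)[C@@H](CC[C@H]1[C@]3(C)CC[C@H](OC(=O)c4ccccc4)C(C)(C)O[C@H]3CC[C@@]1(C)O)C2(C)C` gives 18400 nM. Compound 2 `CC1=CC[C@H]2[C@H](CC[C@]2(C)O)C(C)(C)[C@@H]1CC[C@H]1[C@]2(C)CC[C@H](OC(=O)NCc3ccccc3)C(C)(C)O[C@H]2CC[C@@]1(C)O` gives 40300 nM, and compound 3 `CC1=CC[C@H]2[C@H](CC[C@]2(C)O)C(C)(C)[C@@H]1CC[C@H]1[C@]2(C)CC/C(=N/O)C(C)(C)O[C@H]2CC[C@@]1(C)O` gives 42700 nM. On these numbers compound 2 stands second highest of the three: its value and that of compound 3 lie within the scatter of each other, while compound 1 sits beyond the scatter at a lower number. Compound 4 `CC1=CC[C@H]2[C@H](CC[C@]2(C)O)C(C)(C)[C@@H]1CC[C@H]1[C@]2(C)CC[C@H](OC(=O)c3ccc(C(F)(F)F)cc3F)C(C)(C)O[C@H]2CC[C@@]1(C)O` has not yet been measured. It differs from compound 2 in one place: 2-fluoro-4-(trifluoromethyl)phenyl in place of benzylamino on a carbonyl carbon. Because compound 1 gives 18400 nM on a core that differs from that of compound 2, a move toward a lower number is expected for compound 4. The expected step is a 1.6-fold lower number from compound 2 to compound 4 (0.21 log units; within the scatter), probably near the edge of the scatter. Compound 4 is estimated at 25000 nM, between 10000 nM and 60000 nM.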

Compound 4, half-maximal inhibitory concentration: 36300 nM
Compound 4: middle estimate off by 1.5-fold (0.16 log units), on the low side, within the range that was stated.
By their numbers in this assay, from the lowest: compounds 1, 4, 2 and 3 (each within the scatter of the next, the first and the last beyond it).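

In this assay, 2-fluoro-4-(trifluoromethyl)phenyl in place of benzylamino on a carbonyl carbon gives a 1.1-fold lower number from compound 2 to compound 4 (0.05 log units; within the scatter) and so stays within the scatter. At this position, then, the pair shows that losing the hydrogen-bond donor of benzylamino and taking on a larger group does not move the number beyond the scatter. Nothing shown offers an explanation for this result. Still open, on these data alone, is whether a methyl group, a cyclohexyl ring or a longer alkyl chain on that carbonyl carbon would move the number beyond the scatter.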